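Amide ring size and dipeptidyl peptidase inhibition

The source may hold more compounds than are shown below. What is called first, only, known or untested is meant among the compounds shown, and "the series" means these compounds.

Compound 1, `N#C[C@@H]1CCCN1C(=O)[C@@H]1C[C@H](C(=O)N2CCCCC2)CN1`: in an assay on the whole organism (plasma, strain Sprague-Dawley) for inhibition of Dipeptidyl peptidase 4 (Rattus norvegicus), with a stated time of 10 h, at a dose of 1 mg/kg by the oral route (a higher number here means more inhibition at the dose given (going by the name of the read-out), a lower number less inhibition), compound 1 gives 50%.
Compound 2, `CCN(C)C(=O)[C@@H]1CN[C@H](C(=O)N2CCC[C@H]2C#N)C1`: in this assay compound 2 gives 34%.

Among the compounds with values here, compound 2 stands lowest of the two numbers; the single measured step, a number 16 percentage points lower from compound 1 to compound 2 (beyond the scatter), is the one that bears on the next change. Compound 3, `N#C[C@@H]1CCCN1C(=O)[C@@H]1C[C@H](C(=O)N2CCC2)CN1`, differs from compound 2 by azetidin-1-yl in place of ethyl(methyl)amino on a carbonyl carbon. Within the data shown here, this change runs counter to the one measured step, closing the acyclic amine into a small ring rather than opening a ring, so a modest rise is expected, a number 8 percentage points higher from compound 2 to compound 3 (within the scatter), though a smaller ring than in compound 1 gives no firm guide. Compound 3 is estimated at 42%, within a range of 28% to 58%.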

Compound 3, a percentage reported as inhibition, in the whole organism at one dose (the size of the read-out at that dose, not a potency): 46%
For compound 3 the middle estimate is 4 percentage points below the measured one; the measured number falls inside the stated range.
By their numbers in this assay, from the lowest: compound 2; then compounds 3 and 1 (each within the scatter of the next).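

Closing the open-chain amine into a ring with the same count of 4 heavy atoms on the carbonyl carbon is a real change in this assay: a number 12 percentage points higher from compound 2 to compound 3 (beyond the scatter). Ring size shows no readable effect, since azetidin-1-yl and piperidin-1-yl differ only by a number 4 percentage points lower from compound 1 to compound 3 (within the scatter), so both cyclic amides in these three compounds stand clear of the ethyl(methyl)amino amide. No measurement here gives a reason for the ring effect.

Still open, as far as these compounds go, is whether pyrrolidin-1-yl or morpholin-4-yl on the same carbonyl carbon would stay at the level of compound 3.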